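The source may report more compounds than this note shows. Statements on the series, on what has been measured and on what is new or still open speak of the compounds shown alone.

Of the compounds shown here, three sharing one core have been measured in a functional assay on KB cells (Homo sapiens) for cytotoxicity, read by MTT assay, with a stated time of 3 days; on this read-out higher numbers stand for weaker inhibition and lower numbers for stronger inhibition. There, compound 1 `N#Cc1c(O)nc(SCc2nc3ccccc3[nH]2)nc1-c1ccccc1` gives 6.2 nM, compound 2 `N#Cc1c(Cl)nc(SCc2nc3ccccc3[nH]2)nc1-c1ccccc1` gives 3.7 nM and compound 3 `N#Cc1c(Nc2ccccn2)nc(SCc2nc3ccccc3[nH]2)nc1-c1ccccc1` gives 7.35 nM. Compound 3 lies within the scatter of both other compounds, so these numbers do not separate the three. The next compound, compound 4 `N#Cc1c(NC(N)=O)nc(SCc2nc3ccccc3[nH]2)nc1-c1ccccc1`, differs from compound 3 by carbamoyl in place of pyridin-2-yl on a nitrogen on an aromatic ring, which turns the (pyridin-2-yl)amino group into a ureido group.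

Among the compounds with values here, no measured step makes this exact change, so the nearest evidence is the three steps among the groups on the same aromatic carbon. These are a 1.7-fold lower number from compound 1 to compound 2 (0.22 log units; within the scatter), a 1.2-fold higher number from compound 1 to compound 3 (0.07 log units; within the scatter) and a 2.0-fold higher number from compound 2 to compound 3 (0.30 log units; within the scatter). Each stays within the scatter, and the step that removes the (pyridin-2-yl)amino group from compound 3 in favour of the hydroxy of compound 1 is the same size as a 1.2-fold higher number from compound 1 to compound 3 (0.07 log units; within the scatter). A ureido group has not been measured, so this evidence is indirect. On this basis, no step beyond the scatter is expected in this assay, and no direction is favoured. The estimated change is a 1.1-fold lower number from compound 3 to compound 4 (0.05 log units; within the scatter). Compound 4 is expected at 6.5 nM, with an estimated range from 2.5 nM to 17 nM.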

Compound 4, half-maximal inhibitory concentration: 9.6 nM
For compound 4 the middle estimate is 1.5-fold (0.17 log units) below the measured one; the measured number falls inside the stated range.
By their numbers in this assay, from the lowest: compounds 2, 1, 3 and 4 (each within the scatter of the next, the first and the last beyond it).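

In this assay, replacing pyridin-2-yl with carbamoyl on the nitrogen on an aromatic ring gives a 1.3-fold higher number from compound 3 to compound 4 (0.12 log units; within the scatter), which shows that this nitrogen can carry either a six-membered aromatic ring or a group with no ring without a step beyond the scatter. Within the data shown here, the ureido group also remains within the scatter of hydroxy on the same aromatic carbon, with a 1.5-fold higher number from compound 1 to compound 4 (0.19 log units; within the scatter), but exchanging chloro for ureido gives a 2.6-fold higher number from compound 2 to compound 4 (0.41 log units; beyond the scatter), the only modest step beyond the scatter among the compounds at this position and the first to separate two of them. No supporting evidence is available to explain these differences.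

The compounds shown leave open whether a simple amine, a carboxylic acid or a longer alkyl chain on this aromatic carbon would remain in the same range or move clearly away from it. They also leave open whether the separation between the chloro and ureido compounds would recur in cells other than those used here.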